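Aminopyridyl replacement at the core aryl position

The source may report more compounds than this note shows. Statements on the series, on what has been measured and on what is new or still open speak of the compounds shown alone.

Compound 2 `Nc1ccc(-c2cnc3[nH]cc(-c4ccncc4)c3c2)cc1` carries the highest number of the three measured in a functional assay on MCF7 cells (Homo sapiens) for cytotoxicity, read by MTT assay, with a stated time of 48 h (a lower number here means a stronger inhibitor, a higher number a weaker inhibitor), compound 2 giving 7700 nM, though its gap to compound 3 lies within the scatter. Compound 1 `Nc1cccc(-c2cnc3[nH]cc(-c4ccncc4)c3c2)c1` gives 2300 nM and compound 3 `Nc1cc(NS(=O)(=O)c2ccc(F)cc2F)cc(-c2cnc3[nH]cc(-c4ccncc4)c3c2)c1` gives 6600 nM. Among the compounds with values here, the one measured step, a 3.3-fold higher number from compound 1 to compound 2 (0.52 log units; beyond the scatter), relocates the amine on the same carbon-only ring rather than exchanging the ring itself. Compound 4 `Nc1cncc(-c2cnc3[nH]cc(-c4ccncc4)c3c2)c1` differs from compound 2 by 5-aminopyridin-3-yl in place of 4-aminophenyl on an aromatic carbon. Within the data shown here, no measured step bears directly on an exchange of 4-aminophenyl for 5-aminopyridin-3-yl; the only step on hand concerns the amine. The expected step is therefore a 1.1-fold lower number from compound 2 to compound 4 (0.04 log units; within the scatter), with no direction beyond the scatter. Compound 4 is estimated at 7000 nM, between 2500 nM and 20000 nM.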

Compound 4, half-maximal inhibitory concentration: 5100 nM
Compound 4: middle estimate off by 1.4-fold (0.14 log units), on the high side; the measured number falls inside the stated range.
By their numbers in this assay, from the lowest: compound 1; then compounds 4, 3 and 2 (each within the scatter of the next).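

Placing a ring nitrogen in the aryl group at this position, with 5-aminopyridin-3-yl in place of 4-aminophenyl, gives no readable shift in this assay (a 1.5-fold lower number from compound 2 to compound 4 (0.18 log units; within the scatter)). Set against the 3-aminophenyl group, the same 5-aminopyridin-3-yl group does give a modest shift that clears the scatter (a 2.2-fold higher number from compound 1 to compound 4 (0.35 log units; beyond the scatter)), so the ring nitrogen does not reach the number of compound 1. No measurement on hand explains either step. Open, on these data alone, is whether a hydroxyl or a carboxylic acid in place of the amine on the 5-aminopyridin-3-yl ring would move the number beyond the scatter.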